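The source may report more compounds than this note shows. Statements on the series, on what has been measured and on what is new or still open speak of the compounds shown alone.

In a functional assay on MDA-MB-231 cells (Homo sapiens) for antiproliferative activity, read by MTT assay, with a stated time of 72 h (on this read-out lower numbers stand for stronger inhibition and higher numbers for weaker inhibition), compound 1 (`CC1=CC[C@H]2[C@H](CC[C@]2(C)O)C(C)(C)[C@@H]1CC[C@H]1[C@]2(C)CC[C@H](OC(=O)c3ccc(Cl)cc3)C(C)(C)O[C@H]2CC[C@@]1(C)O`) gives 10300 nM, compound 2 (`CC1=CC[C@H]2[C@H](CC[C@]2(C)O)C(C)(C)[C@@H]1CC[C@H]1[C@]2(C)CC[C@H](OCc3ccccc3)C(C)(C)O[C@H]2CC[C@@]1(C)O`) gives 29100 nM and compound 3 (`CC1=CC[C@H]2[C@H](CC[C@]2(C)O)C(C)(C)[C@@H]1CC[C@H]1[C@]2(C)CC[C@H](OC(=O)c3ccccc3Cl)C(C)(C)O[C@H]2CC[C@@]1(C)O`) gives 24300 nM. Compound 3 therefore stands level with compound 2, as a 1.2-fold lower number from compound 2 to compound 3 (0.08 log units; within the scatter) shows, and apart from compound 1. Compound 4 (`CC1=CC[C@H]2[C@H](CC[C@]2(C)O)C(C)(C)[C@@H]1CC[C@H]1[C@]2(C)CC[C@H](OC(=O)c3ccc([N+](=O)[O-])o3)C(C)(C)O[C@H]2CC[C@@]1(C)O`) has 5-nitrofuran-2-yl in place of 2-chlorophenyl on a carbonyl carbon. Among the compounds with values here, the only measured change at that carbonyl carbon is modest, a 2.4-fold higher number from compound 1 to compound 3 (0.37 log units; beyond the scatter). The ester-to-ether step, a 2.8-fold higher number from compound 1 to compound 2 (0.45 log units; beyond the scatter), bears on it less directly. Within the data shown here, no measured compound carries a five-membered aromatic ring, so the direction is poorly fixed. No step beyond the scatter is expected in this assay: the expected step is a 1.5-fold lower number from compound 3 to compound 4 (0.18 log units; within the scatter). For compound 4 the estimated value is 16000 nM, with an expected range of 6000 nM to 40000 nM.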

Compound 4, half-maximal inhibitory concentration: 11100 nM
Compound 4: middle estimate off by 1.4-fold (0.16 log units), on the high side; the range from low to high includes it.
By their numbers in this assay, from the lowest: compounds 1 and 4 (each within the scatter of the next); then compounds 3 and 2 (each within the scatter of the next).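

In this assay, the carbonyl carbon accepts a five-membered aromatic ring as well as a six-membered one: 5-nitrofuran-2-yl stands level with 4-chlorophenyl, with a 1.1-fold higher number from compound 1 to compound 4 (0.03 log units; within the scatter) as the step. The same group separates from the 2-chlorophenyl ester, with a 2.2-fold lower number from compound 3 to compound 4 (0.34 log units; beyond the scatter) as the step, and from the benzyl ether, with a 2.6-fold lower number from compound 2 to compound 4 (0.42 log units; beyond the scatter) as the step, so the ester link alone does not set the level, as compound 3 shows. Nothing available accounts for these steps.

Open, going by these compounds, is whether the furan ring or the nitro group carries the step away from compound 3. A furan without the nitro group, or one bearing an amine in its place, would separate the two.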